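A dihydroxyphenyl in place of dichlorophenyl on a shared core

A few compounds are considered here, and "the series" means these few. Any claim that something is new, unique, unknown or untested is made for them only; others in the source may bear on it.

In a functional assay on K562 cells (Homo sapiens) for antiproliferative activity, with a stated time of 72 h (a higher number here means a weaker inhibitor, a lower number a stronger inhibitor), compound 3 `OC[C@H]1O[C@@H](n2cnc3c(NCc4ccc(Cl)cc4Cl)ncnc32)[C@H](O)[C@@H]1O` gives 106000 nM, the highest of the two numbers recorded. Compound 1 `OC[C@H]1O[C@@H](n2cnc3c(NCc4cccc(F)c4)ncnc32)[C@H](O)[C@@H]1O` gives 7600 nM, and the step of a 14-fold higher number from compound 1 to compound 3 (1.14 log units; beyond the scatter) bears on the present comparison. Compound 2 `COc1cccc(CNc2ncnc3c2ncn3[C@@H]2O[C@H](CO)[C@@H](O)[C@H]2O)c1` reaches only a limit of the assay, > 166000 nM. The step of an at least 1.5-fold lower number from compound 2 to compound 3 (0.19 log units; that floor lies within the scatter) is the other relevant one. Compound 4 `OC[C@H]1O[C@@H](n2cnc3c(NCc4cc(O)cc(O)c4)ncnc32)[C@H](O)[C@@H]1O` has not yet been measured; it differs from compound 3 as 3,5-dihydroxyphenyl in place of 2,4-dichlorophenyl on a saturated chain carbon bound to a nitrogen on an aromatic ring. Among the compounds with values here, no measured step covers this exact change, but moving from the fluoro-bearing compound 1 to the methoxy-bearing compound 2 weakened inhibition sharply, so the number for compound 4 is expected to stay high, with a 1.4-fold higher number from compound 3 to compound 4 (0.15 log units; within the scatter) expected to be small or none beyond the scatter. The estimate for compound 4 is 150000 nM, between 40000 nM and 500000 nM.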

Compound 4, half-maximal inhibitory concentration: > 166000 nM
Compound 4: a limit, no number (the forecaster's own chance of this, stated with the estimate: 50%); middle value at least 1.1-fold (0.04 log units) from the limit.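

In this assay compound 4 stands at a limit of the assay and not at a number, which makes 3,5-dihydroxyphenyl the second group at this place to do so: the limit of > 166000 nM in this assay, at which 2 of the 4 values shown sit. The change gives an at least 21-fold higher number from compound 1 to compound 4 (1.33 log units; beyond the scatter) and also an at least 1.5-fold higher number from compound 3 to compound 4 (0.19 log units; that floor lies within the scatter) so hydroxyl groups on this ring do not bring back the number of compound 1. The step between compound 2 and compound 4 cannot be read, since both are limits. On these data alone, whether a single hydroxyl, an amine or a carboxylic acid on this ring, or a longer chain to it, would come closer to compound 1 stays open.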